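Clearance after swapping the nitrile pyridine for an oxazole

The compounds below may be only part of what the source reports. "The series", "measured", "known", "first", "only" and "open" are said of these compounds alone.

Measured in an ADME assay on the whole organism (strain Sprague-Dawley) for pharmacokinetics, with Rattus norvegicus as the target, read by LC-MS, using cassette dosing, at a dose of 0.5 mg/kg by the intravenous route; on this read-out lower numbers stand for slow clearance and higher numbers for fast clearance:
- compound 1 `C[C@@]1(c2cc(NC(=O)c3cnc(OCF)cn3)ccc2F)C=C(CF)OC(N)=N1`: 34.4 mL/min/kg
- compound 2 `C[C@@]1(c2cc(NC(=O)c3coc(C(F)F)n3)ccc2F)C=C(CF)OC(N)=N1`: 28.4 mL/min/kg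
- compound 3 `C[C@@]1(c2cc(NC(=O)c3ccc(C#N)cn3)ccc2F)C=C(CF)OC(N)=N1`: 16.8 mL/min/kg

Compound 3 stands at the low end of these three values, with a 2.0-fold lower number from compound 1 to compound 3 (0.31 log units; beyond the scatter) and a 1.7-fold lower number from compound 2 to compound 3 (0.23 log units; within the scatter). Compound 4 `C[C@@]1(c2cc(NC(=O)c3coc(CF)n3)ccc2F)C=C(CF)OC(N)=N1` has not yet been measured. It differs from compound 3 by one change, 2-(fluoromethyl)-1,3-oxazol-4-yl in place of 5-cyanopyridin-2-yl on a carbonyl carbon. The closest guide is the measured exchange of 2-(difluoromethyl)-1,3-oxazol-4-yl for 5-cyanopyridin-2-yl, a 1.7-fold lower number from compound 2 to compound 3 (0.23 log units; within the scatter). Run in reverse, it suggests a rise of similar size, close to the scatter. The expected change is a 1.7-fold higher number from compound 3 to compound 4 (0.22 log units; within the scatter). For compound 4 the estimated clearance is 28 mL/min/kg, with an expected range of 16 mL/min/kg to 48 mL/min/kg.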

Compound 4, clearance: 55 mL/min/kg
Estimate against measurement, compound 4: 2.0-fold (0.29 log units) below, and the stated range ends below it.
By their numbers in this assay, from the lowest: compounds 3, 2, 1 and 4 (each within the scatter of the next, the first and the last beyond it).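

In this assay, 2-(fluoromethyl)-1,3-oxazol-4-yl in place of 5-cyanopyridin-2-yl on the carbonyl carbon gives a 3.3-fold higher number from compound 3 to compound 4 (0.52 log units; beyond the scatter), so this oxazole does not keep the low number of compound 3. The other two steps stay inside the scatter: a 1.9-fold higher number from compound 2 to compound 4 (0.29 log units; within the scatter) and a 1.6-fold higher number from compound 1 to compound 4 (0.20 log units; within the scatter). The 5-cyanopyridin-2-yl group therefore stands apart from the groups in compound 1 and compound 4, though compound 2 goes against a clean split, lying within the scatter of compound 3.

Nothing measured here accounts for the rise. Open too, from the compounds shown here alone, is how a trifluoromethyl group on the same oxazole would read.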